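This account rests on a few compounds, and the source may have more. Where it says the series, first, only, none or still open, it means among the compounds named here.

Among the compounds with values here, in a functional assay on A549 cells (Homo sapiens) for cytotoxicity, read by sulforhodamine B assay (a higher number here means a weaker inhibitor of growth, a lower number a stronger inhibitor of growth), two compounds have numbers so far. Compound 1 (`Cc1nc(N2CCCc3cc(Br)ccc32)c2ccccc2n1`) gives 211 nM in this read-out of growth inhibition. Compound 2 (`COc1ccc2c(c1)CCCCN2c1nc(Cl)nc2ccccc12`) gives 191 nM and so stands level with compound 1, the two values lying within the scatter of each other. Compound 3 (`COc1ccc2c(c1)CCCCN2c1nc(C)nc2ccccc12`) keeps the core of compound 2 but has methyl in place of chloro on an aromatic carbon, between two ring nitrogen atoms (methyl in place of chloro on an aromatic carbon). Within the data shown here, no measured pair isolates this change. The expectation rests on compound 1, which bears a methyl at that place and still gives 211 nM in this assay, although it also differs from compound 2 elsewhere. No step beyond the scatter is therefore expected, with only a slight lean towards a lower number. The estimated change is a 1.5-fold lower number from compound 2 to compound 3 (0.17 log units; within the scatter) in all. Compound 3 is expected at 130 nM, with an estimated range from 35 nM to 450 nM for repeat measurements.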

Compound 3, concentration for 50% growth inhibition: 21 nM
Estimate against measurement, compound 3: 6.2-fold (0.79 log units) above; measured number outside the range, below it.
By their numbers in this assay, from the lowest: compound 3; then compounds 2 and 1 (each within the scatter of the next).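

In this assay, methyl in place of chloro on the aromatic carbon between two ring nitrogen atoms gives a 9.1-fold lower number from compound 2 to compound 3 (0.96 log units; beyond the scatter), which shows that the number responds to the group held at this position. Within the data shown here, one heavy atom replaces one heavy atom here, with no ring, hydrogen-bond donor, hydrogen-bond acceptor or net charge entering or leaving, yet the step lies beyond the scatter, something no earlier pair could show. Nothing measured here accounts for the size of this step.

With only chloro and methyl shown at this position, it remains open whether an amine or a longer chain such as ethyl would give a number nearer compound 3 or compound 2. On these data alone, it also remains open whether the same change would give a similar step on the core of compound 1.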